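A few compounds are considered here, and "the series" means these few. Any claim that something is new, unique, unknown or untested is made for them only; others in the source may bear on it.

Measured compounds:
compound 1, `O=C(O)Cc1sc(Cc2ccccc2-c2ccccc2)nc1-c1ccc(Cl)cc1`, gives 50% in an in vitro functional assay on HEK285-7 cells for antagonist activity at prostaglandin D2 receptor 2 (Homo sapiens), read by BRET and beta-arrestin recruitment; a lower number here means a smaller maximal response, a higher number a larger maximal response;
compound 2, `CS(=O)(=O)Nc1cccc(-c2nc(C(c3ccc(F)cc3)c3ccc(F)cc3)sc2CC(=O)O)c1`, gives 80% in this assay;
compound 3, `O=C(O)Cc1sc(C(c2ccccc2)c2ccccc2)nc1-c1ccccc1`, gives 80% in this assay.

Among these three, compound 2 stands level with compound 3 at the digits shown, and together they give the highest maximal response of the set; the difference between the two lies within the usual scatter, so no order can be read from it. Compound 1 is the furthest away, with a lower number, and that gap is beyond the scatter.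

Compound 4, `O=C(O)Cc1sc(C(c2ccc(F)cc2)c2ccc(F)cc2)nc1-c1ccccc1`, has not yet been measured in this assay. It differs from compound 2 in one place: hydrogen in place of methanesulfonamido on an aromatic carbon. The change sits on the six-membered aromatic ring of carbon only, meta to a large group, and leaves the rest of the shared core untouched.

For the measured compounds named here, no pair of measured compounds shows this exact change, so its effect on the maximal response is not known from the data. Compound 3, which also carries a plain phenyl at this position, gives 80%, the same number as compound 2. For that reason the step of a number 2 percentage points lower from compound 2 to compound 4 (within the scatter) is expected to be small, with no change beyond the scatter in either direction. For compound 4 the estimated maximal response is 78%, with a range from 62% to 92%.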

Compound 4, largest response reached (reported as efficacy), in percent of the reference or control that the assay uses: 80%
For compound 4 the middle estimate is 2 percentage points below the measured one, and the stated range covers the measured number.
By their numbers in this assay, from the lowest: compound 1; then compounds 2, 3 and 4 (each within the scatter of the next).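

For the compounds shown here, this is the first pair in the set that differs in one place, so the contribution of one group can now be read directly. In this assay, the change from 3-(methanesulfonamido)phenyl to phenyl gives no change at the digits printed from compound 2 to compound 4 (within the scatter), even though it removes a group of five heavy atoms, with its hydrogen-bond donor and acceptors, and leaves only hydrogen on the aromatic carbon. On this scaffold, then, the methanesulfonamido group is not needed to keep the maximal response at this level, and the position accepts a plain hydrogen as well as this much larger group; no available measurement explains why.

A single change cannot show whether this position is insensitive to substitution in general, and an amine, a carboxylic acid or a longer chain on the same aromatic carbon could still move the maximal response beyond the scatter. On these data alone, it also remains open whether the same swap would have as little effect on a different core, such as that of compound 1, which gives 50% in this assay and differs from compound 2 in more than one place.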